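Amide cap variation on the octadecyl threonine series

The compounds below may be only part of what the source reports. "The series", "measured", "known", "first", "only" and "open" are said of these compounds alone.

Measured so far in a functional assay on MCF7 cells (Homo sapiens) for cytotoxicity, read by MTT assay, with a stated time of 48 h; a higher number here means a weaker inhibitor, a lower number a stronger inhibitor:
compound 1, `CCCCCCCCCCCCCCCCCCNC(=O)[C@@H](NC(=O)c1ccco1)[C@@H](C)O`, gives 21400 nM;
compound 2, `CCCCCCCCCCCCCCCCCCNC(=O)[C@@H](NC(=O)c1cc2ccccc2o1)[C@@H](C)O`, gives 126000 nM;
compound 3, `CCCCCCCCCCCCCCCCCCNC(=O)[C@@H](NC(=O)c1nccc2ccccc12)[C@@H](C)O`, gives 30800 nM.

Compound 3 stands second highest of the three numbers. Compound 1 lies close to it (a 1.4-fold higher number from compound 1 to compound 3 (0.16 log units; within the scatter)), whereas compound 2 sits well apart (a 4.1-fold lower number from compound 2 to compound 3 (0.61 log units; beyond the scatter); see also a 5.9-fold higher number from compound 1 to compound 2 (0.77 log units; beyond the scatter)).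

Compound 4, `C/C=C/C=C/C(=O)N[C@H](C(=O)NCCCCCCCCCCCCCCCCCC)[C@@H](C)O`, differs from compound 3 by penta-1,3-dien-1-yl in place of isoquinolin-1-yl on a carbonyl carbon. Within the data shown here, none of the measured steps exchanges a ring for an open chain; all three swap one aromatic cap for another, and the two caps of compound 1 and compound 3 sit together while compound 2 is higher. Among the measured compounds shown here, with no direct precedent, a step within the scatter is expected for compound 4: a 1.2-fold lower number from compound 3 to compound 4 (0.09 log units; within the scatter). Compound 4 is therefore estimated at 25000 nM, with a range from 8000 nM to 80000 nM in this assay.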

Compound 4, half-maximal inhibitory concentration: 79600 nM
Estimate against measurement, compound 4: 3.2-fold (0.50 log units) below; the range from low to high includes it.
By their numbers in this assay, from the lowest: compounds 1 and 3 (each within the scatter of the next); then compounds 4 and 2 (each within the scatter of the next).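

In this assay the open-chain penta-1,3-dien-1-yl cap, the only cap here without a ring, gives a number set apart from the two lower caps (a 2.6-fold higher number from compound 3 to compound 4 (0.41 log units; beyond the scatter); a 3.7-fold higher number from compound 1 to compound 4 (0.57 log units; beyond the scatter)). It stays within the scatter of the 1-benzofuran-2-yl cap (a 1.6-fold lower number from compound 2 to compound 4 (0.20 log units; within the scatter)), so this carbonyl position separates the caps by more than the presence of a ring alone. No measurement on hand explains these steps. Open, on these data alone, is whether a saturated pentyl chain would read like the diene. Also open, as far as these compounds go, is how an amine or carboxylic acid on the cap would read.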